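Methoxy on the aromatic ring of compound 2

A few compounds are considered here, and "the series" means these few. Any claim that something is new, unique, unknown or untested is made for them only; others in the source may bear on it.

The series holds three measured compounds built on one shared core, differing in the ring that carries the imine nitrogen. Compound 1 `c1ccc(C(/N=C2\CCCCN2)C2CC2)cc1` gives 36% in a functional assay on the whole organism (plasma, strain Sprague-Dawley) with Rattus norvegicus as the target, with a stated time of 2 h, at a dose of 100 mg/kg by the oral route; a higher number here means a stronger effect of the compound at the dose given, a lower number a weaker effect. Compound 2 `c1ccc(C(/N=C2\CCCCCN2)C2CC2)cc1` gives 51% in this assay, and compound 3 `c1ccc(C(/N=C2\CCCCCCN2)C2CC2)cc1` gives 58% in this assay.

Within these three numbers compound 2 stands second highest. Its nearest neighbour is compound 3, whose number is higher by an amount within the usual scatter, so no order between compound 2 and compound 3 can be read from the data. Its furthest neighbour is compound 1, whose number is lower by an amount beyond the scatter; compound 2 therefore gives a clearly stronger effect than compound 1 at this dose.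

Compound 4 `COc1ccc(C(/N=C2\CCCCCN2)C2CC2)cc1` is not yet measured. It differs from compound 2 in one place: methoxy in place of hydrogen on an aromatic carbon. Within the data shown here, no step of this kind has been measured anywhere, so there is no precedent for its size or direction in this assay. The change leaves the core and the imine ring untouched, and the expectation is a step of no more than the scatter in either direction. The step from compound 2 to compound 4 is estimated as a number 1 percentage points lower from compound 2 to compound 4 (within the scatter). Compound 4 is expected to give 50% in this assay, with a range from 30% to 70%.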

Compound 4, a percentage reported as inhibition, in the whole organism at one dose (the size of the read-out at that dose, not a potency): 40%
For compound 4 the middle estimate is 10 percentage points above the measured one; measured number inside the range.
By their numbers in this assay, from the lowest: compounds 1 and 4 (each within the scatter of the next); then compounds 2 and 3 (each within the scatter of the next).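

In this assay, among these compounds, the first measured change on the aromatic ring gives a step that can be read: methoxy in place of hydrogen, para to a large group, brings a number 11 percentage points lower from compound 2 to compound 4 (beyond the scatter) and so shows that this aromatic carbon is not indifferent to substitution at the dose given. The earlier compounds shown here differ only in the ring that carries the imine nitrogen, so they could say nothing about this position. Among the compounds shown here, the step is modest and is the only reading of this change so far, and no measurement at hand bears on what lies behind it.

As far as these compounds go, whether fluorine, hydroxyl or a dimethylamino group on the same aromatic carbon lowers the read-out as methoxy does remains open, as does the outcome with ethoxy, the next longer chain. Also open, from the compounds shown here alone, is whether methoxy at this place gives a step of similar size and the same direction on the imine rings of compound 1 and compound 3, so the result holds for the pair of compound 2 and compound 4 alone.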